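This account rests on a few compounds, and the source may have more. Where it says the series, first, only, none or still open, it means among the compounds named here.

Measured in a physicochemical assay for solubility, read by HPLC, using the shake flask method, measured as kinetic solubility, with a stated time of 20 h, at pH 6.5, tested at 200 uM; on this read-out higher numbers stand for higher solubility and lower numbers for lower solubility:
- Compound 1 `O=S(=O)(NCC1COC1)c1cccc(-c2ccc3nccc(-c4ccncc4)c3n2)c1`: 20000 nM
- Compound 2 `O=S(=O)(c1cccc(-c2ccc3nccc(-c4ccncc4)c3n2)c1)N1CCC(O)CC1`: 10000 nM
- Compound 3 `NS(=O)(=O)c1cccc(-c2ccc3nccc(-c4ccncc4)c3n2)c1`: < 5000 nM

Compound 3 gives < 5000 nM, which is a limit of the assay and not a number. Compound 4 `Cc1ccc(-c2ccnc3ccc(-c4cccc(S(N)(=O)=O)c4)nc23)cn1` carries 6-methylpyridin-3-yl in place of pyridin-4-yl on an aromatic carbon. The measured steps all alter what sits on the sulfonyl sulfur: a 2.0-fold lower number from compound 1 to compound 2 (0.30 log units; within the scatter), an at least 4.0-fold lower number from compound 1 to compound 3 (0.60 log units; beyond the scatter) and an at least 2.0-fold lower number from compound 2 to compound 3 (0.30 log units; that floor lies within the scatter). None of them touches the pyridin-4-yl group, so they give no size for this change. The expected result in this assay is therefore no step beyond the scatter, with an estimated step that the limit leaves unreadable from compound 3 to compound 4. The estimate for compound 4 is 4000 nM, within an expected range of 1500 nM to 12000 nM.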

Compound 4, solubility: < 5000 nM
Compound 4: only a limit was reported; the forecaster's own chance of this, stated with the estimate: 60%; the middle value does not contradict the limit.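

Compound 3 and compound 4 both sit at a limit, not at a number, in this assay, so no step can be read between them: the limit of < 5000 nM in this assay, at which 2 of the 4 values shown sit.

The compounds shown leave open how large the effect of 6-methylpyridin-3-yl in place of pyridin-4-yl is.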